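Moving a pyridine one carbon out on a triazole amide

The source may report more compounds than this note shows. Statements on the series, on what has been measured and on what is new or still open speak of the compounds shown alone.

The measured compounds so far:
compound 1 `CCc1ccc(Cn2c(CCc3ccccc3)nnc2[C@H](NC(=O)c2ccccn2)c2c[nH]c3ccccc23)cc1` gives 67 nM
compound 2 `CCc1ccc(-n2c(CCc3c[nH]c4ccccc34)nnc2[C@H](NC(=O)c2ccccn2)c2c[nH]c3ccccc23)cc1` gives 49 nM
compound 3 `CCc1ccc(Cn2c(CCc3ccccc3)nnc2[C@H](NC(=O)Cc2ccccn2)c2c[nH]c3ccccc23)cc1` gives 51 nM

These values come from an in vitro assay on LLC-PK1 cells for displacement of a labelled ligand from growth hormone secretagogue receptor type 1 (Homo sapiens); on this read-out lower numbers stand for stronger inhibition and higher numbers for weaker inhibition. The three numbers lie close to each other, and none of the gaps between them is beyond the usual scatter of this assay, so no order among them can be claimed. Compound 3 differs from compound 1 by one change, ((pyridin-2-yl)methyl in place of pyridin-2-yl on a carbonyl carbon), and that change gave a 1.3-fold lower number from compound 1 to compound 3 (0.12 log units; within the scatter). Compound 2 carries a different core from compound 1; the difference between the two cores is not broken down here.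

Compound 4 `CCc1ccc(-n2c(CCc3c[nH]c4ccccc34)nnc2[C@H](NC(=O)Cc2ccccn2)c2c[nH]c3ccccc23)cc1` has not been measured yet. Within the data shown here, it differs from compound 2 by (pyridin-2-yl)methyl in place of pyridin-2-yl on a carbonyl carbon, the same change, at a place described in the same words, as the one between compound 1 and compound 3. The earlier step, a 1.3-fold lower number from compound 1 to compound 3 (0.12 log units; within the scatter), stayed within the scatter, so a step of similar size is expected here: the estimate for compound 4 means a 1.2-fold lower number from compound 2 to compound 4 (0.07 log units; within the scatter). Compound 4 is therefore estimated at 42 nM, with a likely range from 20 nM to 90 nM.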

Compound 4, half-maximal inhibitory concentration: 96 nM
The estimate for compound 4 lay 2.3-fold (0.36 log units) below the measured number; measured number outside the range, above it.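

On the core of compound 2, putting (pyridin-2-yl)methyl in place of pyridin-2-yl on the carbonyl carbon gave a 2.0-fold higher number from compound 2 to compound 4 (0.29 log units; within the scatter). Set beside the same change on the other core, the two steps read in opposite directions on paper, yet they cannot be told apart: the same change on two cores in this assay, a 1.3-fold lower number (0.12 log units; within the scatter) from compound 1 to compound 3 and a 2.0-fold higher number (0.29 log units; within the scatter) from compound 2 to compound 4, 2.6-fold (0.41 log units) apart, within the scatter of two such steps. Among these compounds, this shows no reliable gain or loss from the change on either core and no clear sign that the core alters its outcome, but with only one small step per core it does not prove that the change behaves identically on both.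

The compounds shown keep a pyridine ring on this side of the amide, so they leave open whether a longer chain, an amine or a carboxylic acid in that place would give a step beyond the scatter. They also leave open how the change would behave on a third core.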